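Azole replacement at the aryl ether of the series

The source may hold more compounds than are shown below. What is called first, only, known or untested is meant among the compounds shown, and "the series" means these compounds.

Compound 2 `CCCC(Oc1ccc(-n2cc3ccccc3n2)cc1)c1ccc(C(=O)NCCC(=O)O)cc1` gives 290 nM in an assay on cells for displacement of a labelled ligand from Glucagon receptor (Homo sapiens), in the presence of a further agent that is not named here (on this read-out higher numbers stand for weaker inhibition and lower numbers for stronger inhibition), the lowest of the three numbers; compound 1 `O=C(O)CCNC(=O)c1ccc(C(Oc2ccc(-n3cc(C(F)(F)F)cn3)cc2)C2CC2)cc1` gives 1300 nM and compound 3 `CCC(Oc1ccc(-n2cc(C(F)(F)F)cn2)cc1)c1ccc(C(=O)NCCC(=O)O)cc1` gives 1400 nM, each beyond the scatter from compound 2. Among the compounds with values here, the only single-point step, a 1.1-fold higher number from compound 1 to compound 3 (0.03 log units; within the scatter), concerns the saturated chain carbon and not the azole. Compound 4 `CCCC(Oc1ccc(-n2cccn2)cc1)c1ccc(C(=O)NCCC(=O)O)cc1` differs from compound 2 by 1H-pyrazol-1-yl in place of 2H-indazol-2-yl on an aromatic carbon. Within the data shown here, no measured step bears on this change: compounds 1 and 3 carry a pyrazolyl with trifluoromethyl but also differ from compound 2 at the chain, so their values do not separate the two changes. For compound 4 a step of a 5.2-fold higher number from compound 2 to compound 4 (0.71 log units; beyond the scatter) in this assay toward a higher number is expected, with low confidence. Compound 4 is estimated at 1500 nM, between 400 nM and 6000 nM.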

Compound 4, inhibition constant: 4100 nM
Estimate against measurement, compound 4: 2.7-fold (0.44 log units) below; the measured number falls inside the stated range.
By their numbers in this assay, from the lowest: compound 2; then compounds 1 and 3 (each within the scatter of the next); then compound 4.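

In this assay, with the chain held constant, the step of a 14-fold higher number from compound 2 to compound 4 (1.15 log units; beyond the scatter) is large and beyond the scatter. Within the data shown here, this is the first single-point reading of the azole: the position para to a large group responds strongly when 1H-pyrazol-1-yl takes the place of 2H-indazol-2-yl, whereas the earlier step concerned only the chain carbon. Nothing available explains this step.

Still open, from the compounds shown here alone, is whether a substituent on the 1H-pyrazol-1-yl, such as trifluoromethyl, a nitrile or an amine, would recover the number of compound 2 on this same chain. The values shown do not settle this.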